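This account rests on a few compounds, and the source may have more. Where it says the series, first, only, none or still open, it means among the compounds named here.

Of the compounds shown here, three share one core and have been tested in a functional assay on HepG2 cells (Homo sapiens) for inhibition, with a stated time of 72 h; a lower number here means a stronger inhibitor, a higher number a weaker inhibitor. Compound 1 `COc1ccc(NC(=O)Nc2nc(Sc3c[nH]c4ccccc34)cc(N3CCCCC3)n2)cc1` gives 17100 nM. Compound 2 `COc1ccc(NC(=O)Nc2nc(Nc3cc(OC)cc(OC)c3)cc(Sc3c[nH]c4ccccc34)n2)cc1` gives 17400 nM. Compound 3 `COc1ccc(NC(=O)Nc2nc(Sc3c[nH]c4ccccc34)cc(N3CCCC3)n2)cc1` gives 20300 nM. The steps among them, a 1.0-fold higher number from compound 1 to compound 2 (0.01 log units; within the scatter), a 1.2-fold higher number from compound 1 to compound 3 (0.07 log units; within the scatter) and a 1.2-fold higher number from compound 2 to compound 3 (0.07 log units; within the scatter), all stay within the scatter, so compound 2 sits among three numbers that cannot be told apart. Compound 4 `COc1cc(NC(=O)Nc2nc(Nc3cc(OC)cc(OC)c3)cc(Sc3c[nH]c4ccccc34)n2)cc(OC)c1` differs from compound 2 by 3,5-dimethoxyphenyl in place of 4-methoxyphenyl on an amide-type nitrogen. Going by the values given here, no measured step touches this part of the molecule; the three measured steps alter a different substituent, and each stayed within the scatter. The step of no change at the digits printed from compound 2 to compound 4 (within the scatter) is therefore expected to stay within the scatter as well. Compound 4 is estimated at 17400 nM, with a range from 8000 nM to 38000 nM.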

Compound 4, half-maximal inhibitory concentration: 24800 nM
Beside the measured number, compound 4's estimate is 1.4-fold (0.15 log units) below it; measured number inside the range.
By their numbers in this assay, from the lowest: compounds 1, 2, 3 and 4 (each within the scatter of the next).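

In this assay, putting 3,5-dimethoxyphenyl in place of 4-methoxyphenyl on the amide-type nitrogen gives a 1.4-fold higher number from compound 2 to compound 4 (0.15 log units; within the scatter) and is the first step shown at this position. This position therefore joins the substituent varied among compound 1, compound 2 and compound 3 in showing no step beyond the scatter. No available measurement bears on the reason for this result. Open, from the compounds shown here alone, is how the assay would respond at this nitrogen to a phenyl ring carrying a carboxylic acid or an amine, or to a longer alkyl chain.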